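Ring size of the amidine in an ethylene-linked series

The source may report more compounds than this note shows. Statements on the series, on what has been measured and on what is new or still open speak of the compounds shown alone.

Three compounds share a bromo-methoxyphenyl or dichlorothienyl head joined through a two-atom linker to a benzene carrying a cyclic amidine. Compound 2 `COc1ccc(Br)cc1CCc1ccccc1C1=NCCN1` was read in a functional assay on cell membranes for antagonist activity at Melanocortin receptor 4 (Mus musculus), read by radioligand binding (a higher number here means a weaker inhibitor, a lower number a stronger inhibitor), and gives 39 nM. Compound 3 `COc1ccc(Br)cc1CSc1ccccc1C1=NCCCN1` gives 67 nM, and compound 1 `Clc1cc(CSc2ccccc2C2=NCCCN2)c(Cl)s1` gives 2200 nM. Compound 2 gives the lowest number of the three, though compound 3 lies within the scatter of it; only compound 1 lies beyond the scatter.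

Compound 4 `COc1ccc(Br)cc1CCc1ccccc1C1=NCCCN1` has not been measured. It differs from compound 2 by a group of 6 heavy atoms (4 carbon, 2 nitrogen; one six-membered non-aromatic ring with 2 hetero atoms) in place of a group of 5 heavy atoms (3 carbon, 2 nitrogen; one five-membered non-aromatic ring with 2 hetero atoms), on an aromatic carbon.

Compound 3 also carries the six-membered ring and gives 67 nM. The step of a 1.3-fold higher number from compound 2 to compound 4 (0.11 log units; within the scatter) is therefore expected to stay within the scatter, with no clear direction. For compound 4 the estimate is 50 nM, between 15 nM and 180 nM.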

Compound 4, inhibition constant: 220 nM
Compound 4: middle estimate off by 4.4-fold (0.64 log units), on the low side; measured number above the stated range.
By their numbers in this assay, from the lowest: compounds 2 and 3 (each within the scatter of the next); then compound 4; then compound 1.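

In this assay the six-membered ring in place of the five-membered ring on this aromatic carbon gives a 5.6-fold higher number from compound 2 to compound 4 (0.75 log units; beyond the scatter) and shows that ring size is not neutral at this position on the ethylene linker. Compound 3 at 67 nM and compound 4 at 220 nM carry the same six-membered ring, so the number for compound 3 does not carry over to the ethylene linker. No measured evidence bears on the reason for this step.

On these data alone, how a seven-membered ring or an open-chain amidine would read at this position remains open. The five-membered ring on the sulfur-containing linker also remains unplaced.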